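Swapping the acyl group on compound 2

This account rests on a few compounds, and the source may have more. Where it says the series, first, only, none or still open, it means among the compounds named here.

Of the compounds shown here, three have numbers so far in an ADME assay on a cell-free system (plasma, Homo sapiens) for metabolic stability; on this read-out higher numbers stand for a longer-lived compound and lower numbers for a shorter-lived compound. Compound 1 `CCCCCCCCCCCC(=O)Oc1c(-c2ccc(O)c(O)c2)oc2cc(O)cc(O)c2c1=O` gives 1.22 h. Compound 2 `Cc1cn([C@H]2C=C[C@@H](COC(=O)CNNC(=O)c3ccncc3)O2)c(=O)[nH]c1=O` gives 1 h, within the scatter of compound 1. Compound 3 `CCN(CC)C(=O)COC(=O)[C@H]1O[C@@H](Oc2cc3oc(-c4ccc(O)cc4)cc(=O)c3c(O)c2O)[C@H](O)[C@@H](O)[C@@H]1O` gives 0.167 h, beyond the scatter from compound 2.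

Compound 4 `Cc1cn([C@H]2C=C[C@@H](COC(=O)CNC(=O)c3ccncn3)O2)c(=O)[nH]c1=O` differs from compound 2 in one place: (pyrimidin-4-yl)carbonyl in place of ((pyridin-4-yl)carbonyl)amino on an amine nitrogen. In words, (pyrimidin-4-yl)carbonyl stands in place of ((pyridin-4-yl)carbonyl)amino on an amine nitrogen, and the rest of the structure is shared. For the measured compounds named here, no measured pair here differs in only one place, so the data give no direct size for such a step in this assay. No change beyond the scatter is expected, and any lean in direction is weak, slightly towards a shorter half-life. The expected change is a 1.3-fold lower number from compound 2 to compound 4 (0.10 log units; within the scatter), an estimate that stays within the scatter. For compound 4 the estimated half-life is 0.8 h, with an expected range of 0.25 h to 2.5 h.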

Compound 4, half-life: 1 h
Estimate against measurement, compound 4: 1.3-fold (0.10 log units) below; low and high end bracket the measured number.
By their numbers in this assay, from the lowest: compound 3; then compounds 2, 4 and 1 (each within the scatter of the next).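

In this assay, for the compounds shown here, the acyl swap on the amine nitrogen gives no change at the digits printed from compound 2 to compound 4 (within the scatter) and is the first step read at this position. The half-life therefore shows no response to (pyrimidin-4-yl)carbonyl in place of ((pyridin-4-yl)carbonyl)amino, although the change goes from 1 hydrogen-bond donor to 0 hydrogen-bond donors and from a ring with 1 hetero atom to a ring with 2 hetero atoms. No available evidence bears on this result.

This single step changes the ring and removes the amino link together, so the two changes cannot be separated here. On these data alone, whether a benzoyl group or a longer chain acyl group on the same amine nitrogen would also leave the half-life within the scatter remains open.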